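The compounds below may be only part of what the source reports. "The series", "measured", "known", "first", "only" and "open" are said of these compounds alone.

Compound 1 `CCCCN(c1nc2ccccc2o1)[C@H](C)c1ccc(-c2ccccc2-c2nnn[nH]2)cc1` is the reference of this set. In an ADME assay on the whole organism (Macaca fascicularis) for metabolic stability, read by LC-MS, using cassette dosing, at a dose of 1 mg/kg by the oral route (a lower number here means that the compound disappears faster, a higher number that the compound lasts longer), compound 1 gives 3.2 h. Compound 2 `CCCCN(c1nc2c(C(=O)O)cccc2o1)[C@H](C)c1ccc(-c2ccccc2-c2nnn[nH]2)cc1` gives 3.7 h in this assay, and compound 3 `C[C@H](c1ccc(-c2ccccc2-c2nc(=O)o[nH]2)cc1)N(CC1CC1)c1nc2c(C(=O)O)cccc2o1` gives 2.6 h; all three numbers lie within the scatter of one another, so compound 1 is not set apart from either. Among the measured compounds shown here, the only single-change step measured is a 1.2-fold higher number from compound 1 to compound 2 (0.06 log units; within the scatter), a carboxy entering on the core. Compound 4 `CCCCN(c1nc2c(NS(C)(=O)=O)cccc2o1)[C@H](C)c1ccc(-c2ccccc2-c2nnn[nH]2)cc1` carries a different change: methanesulfonamido in place of hydrogen on an aromatic carbon. For the measured compounds named here, no measured step adds this group. Going by the values given here, the one precedent for putting a group onto the core, a 1.2-fold higher number from compound 1 to compound 2 (0.06 log units; within the scatter), stayed within the scatter, so the expected step in this assay is no change at the digits printed from compound 1 to compound 4 (within the scatter), none beyond the scatter. Compound 4 is therefore estimated at 3.2 h, with a range of 1.8 h to 5.6 h.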

Compound 4, half-life: 4.7 h
Compound 4: middle estimate off by 1.5-fold (0.17 log units), on the low side; measured number inside the range.
By their numbers in this assay, from the lowest: compounds 3, 1, 2 and 4 (each within the scatter of the next).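

A second group on this aromatic carbon, methanesulfonamido, again gives a step within the scatter in this assay: a 1.5-fold higher number from compound 1 to compound 4 (0.17 log units; within the scatter), with a sulfur-bearing group in place of hydrogen. Exchanging the carboxy for it, a 1.3-fold higher number from compound 2 to compound 4 (0.10 log units; within the scatter), also stays within the scatter, so hydrogen, carboxy and methanesulfonamido are not told apart at this position in compounds 1, 2 and 4. No measurement at hand gives a reason for these numbers. On these data alone, whether an amine or a methoxy on this carbon would give a step beyond the scatter remains open. So does whether methanesulfonamido behaves alike with a cyclopropylmethyl chain on the nitrogen.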